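Shortening the Carboxy Chain: From Compound 3 to Compound 4

The source may report more compounds than this note shows. Statements on the series, on what has been measured and on what is new or still open speak of the compounds shown alone.

Compound 3 `O=C(O)CCCCCCCCCOc1ccc2c(=O)c(-c3ccc(O)cc3)coc2c1` gives 4 nM in an assay on isolated protein (Cricetulus griseus) for inhibition of aldehyde dehydrogenase, mitochondrial (Homo sapiens) (on this read-out higher numbers stand for weaker inhibition and lower numbers for stronger inhibition), the lowest of the three numbers measured here. Compound 1 `CCOc1ccc2c(=O)c(-c3ccc(O)cc3)coc2c1` gives 40 nM in this assay, and compound 2 `O=c1c(-c2ccc(O)cc2)coc2cc(OCCCCBr)ccc12` gives 270 nM. Compound 4 `O=C(O)CCCCCCOc1ccc2c(=O)c(-c3ccc(O)cc3)coc2c1` differs from compound 3 by carboxy in place of 3-carboxypropyl on a saturated chain carbon, six bonds along the chain from an oxygen on an aromatic ring. Among the compounds with values here, no measured step shortens a carboxy-bearing chain; the only bearings are a 10-fold lower number from compound 1 to compound 3 (1.00 log units; beyond the scatter) and a 68-fold lower number from compound 2 to compound 3 (1.83 log units; beyond the scatter), both of which arrive at compound 3 with a lower number. Cutting the chain of compound 3 back is therefore expected to give up part of that gain, so a modest rise in this assay is expected, a 3.0-fold higher number from compound 3 to compound 4 (0.48 log units; beyond the scatter). Compound 4 is accordingly estimated at 12 nM, with a range from 4 nM to 40 nM.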

Compound 4, half-maximal inhibitory concentration: 9 nM
For compound 4 the middle estimate is 1.3-fold (0.12 log units) above the measured one, and the stated range covers the measured number.
By their numbers in this assay, from the lowest: compound 3; then compound 4; then compound 1; then compound 2.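

In this assay the shorter acid gives up only a small part of the gain, with a 2.3-fold higher number from compound 3 to compound 4 (0.35 log units; beyond the scatter) when the chain is cut back. Its carboxy-ended chain still keeps a clear lead over the other two chains, with a 4.4-fold lower number from compound 1 to compound 4 (0.65 log units; beyond the scatter) and a 30-fold lower number from compound 2 to compound 4 (1.48 log units; beyond the scatter) as well, so the lower number does not depend on the longest chain alone. Nothing available explains these steps.

Going by these compounds, whether a still shorter carboxy chain, or an amine or an ester at the chain end, would hold this level remains open. With only compound 3 and compound 4 carrying the acid, no trend with chain length can be fixed.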